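From Methoxyphenyl to Ethylphenyl on a Prostaglandin Chain

The source may hold more compounds than are shown below. What is called first, only, known or untested is meant among the compounds shown, and "the series" means these compounds.

Measured so far in an in vitro assay on CHO-KI cells for displacement of a labelled ligand from prostaglandin F2-alpha receptor (Homo sapiens); on this read-out lower numbers stand for stronger inhibition and higher numbers for weaker inhibition:
Compound 1 `O=C(O)CCCCCC[C@@H]1[C@@H](CC[C@@H](O)CCc2cccc(F)c2)[C@H](O)C[C@@H]1O`: 42 nM
Compound 2 `COc1ccc(CC[C@H](O)CC[C@@H]2[C@@H](CCCCCCC(=O)O)[C@@H](O)C[C@H]2O)cc1`: 290 nM

Going by the values given here, compound 2 stands at the highest of the two numbers; its nearest neighbour is compound 1, and the only measured step, a 6.9-fold higher number from compound 1 to compound 2 (0.84 log units; beyond the scatter), lies beyond the usual scatter. Compound 3 `CCc1cccc(CC[C@H](O)CC[C@@H]2[C@@H](CCCCCCC(=O)O)[C@@H](O)C[C@H]2O)c1` differs from compound 2 by a single change: 3-ethylphenyl in place of 4-methoxyphenyl on a saturated chain carbon, three bonds along the chain from an oxygen on a saturated carbon. That step has no exact measured parallel. Among the compounds with values here, the one step that bears on it, a 6.9-fold higher number from compound 1 to compound 2 (0.84 log units; beyond the scatter), shows that exchanging the substituted phenyl ring at this chain position can shift this assay by a modest but real amount. Because compound 1 gives 42 nM with a differently substituted ring at the same place, a lower number than compound 2 is expected for compound 3, as an estimated step of a 3.6-fold lower number from compound 2 to compound 3 (0.56 log units; beyond the scatter). Compound 3 is therefore estimated at 80 nM, with a likely range from 25 nM to 300 nM.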

Compound 3, half-maximal inhibitory concentration: 540 nM
For compound 3 the middle estimate is 6.8-fold (0.83 log units) below the measured one; measured number above the stated range.
By their numbers in this assay, from the lowest: compound 1; then compounds 2 and 3 (each within the scatter of the next).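

In this assay the exchange of 4-methoxyphenyl for 3-ethylphenyl gives a 1.9-fold higher number from compound 2 to compound 3 (0.27 log units; within the scatter) and so leaves these two rings indistinguishable, although they carry different groups. The clearer result is a 13-fold higher number from compound 1 to compound 3 (1.11 log units; beyond the scatter) for ethyl in place of fluoro on an aromatic carbon, which shows that the low number of compound 1 depends on the group on the ring and does not come from any substituted ring at this chain position. No measurement shown here gives a reason for either step.

From the compounds shown here alone, it stays open whether a small group such as chloro or methyl on the ring would stay close to compound 1 or move towards compound 3. A 3-methoxyphenyl ring, absent from the compounds shown, would help separate the effect of the group from that of its place on the ring.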